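The source may hold more compounds than are shown below. What is called first, only, known or untested is meant among the compounds shown, and "the series" means these compounds.

Compound 1 `O=C(O)CNC(=O)COc1ccc([C@H]2CC[C@]3(CC2)OOC2(O3)C3CC4CC(C3)CC2C4)cc1` is the only one of the three measured compounds to give a number in a physicochemical assay for solubility, read by nephelometry, in phosphate buffer, measured as kinetic solubility, with a stated time of 30 min, at pH 6.5 (on this read-out higher numbers stand for higher solubility and lower numbers for lower solubility), where compound 1 gives 12.5 ug/mL. Compound 2 `O=C(O)CCCCOc1ccc([C@H]2CC[C@]3(CC2)OOC2(O3)C3CC4CC(C3)CC2C4)cc1` returns only a limit of the assay, < 1.6 ug/mL. Compound 3 `O=C(O)COc1ccc([C@H]2CC[C@]3(CC2)OOC2(O3)C3CC4CC2CC(C3)C4(F)F)cc1` likewise returns only a limit, < 1.6 ug/mL. For the measured compounds named here, the one step that can be sized runs an at least 7.8-fold lower number from compound 1 to compound 2 (0.89 log units; beyond the scatter), a drop that reached (the limit of < 1.6 ug/mL in this assay, at which 2 of the 3 values shown sit). Compound 4 `O=C(O)c1ccc([C@H]2CC[C@]3(CC2)OOC2(O3)C3CC4CC(C3)CC2C4)cc1` differs from compound 1 by carboxy in place of ((carboxymethyl)carbamoyl)methoxy on an aromatic carbon. Going by the values given here, that is the only step that bears on this change, and it removed the same amide-bearing chain while keeping an acid, so a fall of at least modest size is expected for compound 4, giving a 3.1-fold lower number from compound 1 to compound 4 (0.49 log units; beyond the scatter). Compound 4 is thus estimated at 4 ug/mL, within 1.2 ug/mL to 15 ug/mL.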

Compound 4, solubility: < 3.1 ug/mL
Compound 4 gave a limit, no number (the forecaster's own chance of this, stated with the estimate: 30%); middle value at least 1.2-fold (0.11 log units) away from the limit.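

In this assay, replacing the ((carboxymethyl)carbamoyl)methoxy group on the aromatic carbon with a carboxy group gives an at least 4.0-fold lower number from compound 1 to compound 4 (0.60 log units; beyond the scatter), so a carboxy group set directly on the ring does not retain the number seen for compound 1. Going by these compounds, compound 4 gives only a limit, < 3.1 ug/mL, and so its true value remains unknown. The step between compound 2 and compound 4 cannot be read, as both values are limits.

On these data alone, what remains open is how an amine or a simple amide without the carboxy group would read at this position.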